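The source may report more compounds than this note shows. Statements on the series, on what has been measured and on what is new or still open speak of the compounds shown alone.

Compound 1 `CCOC(=O)CCC(=O)N1CCN(CCCOc2cc3c(Nc4ccc(F)c(Cl)c4)ncnc3cc2OC)CC1` gives 61.6% in a functional assay on A549 cells (Homo sapiens) for cytotoxicity, read by MTT assay, with a stated time of 24 h, tested at 60 uM; a lower number here means a stronger effect, a higher number a weaker effect of the compound at the concentration tested.
Compound 2 `CCCCCCCOC(=O)CCC(=O)N1CCN(CCCOc2cc3c(Nc4ccc(F)c(Cl)c4)ncnc3cc2OC)CC1` gives 35.7% in this assay.

Compound 2 stands lowest of the two numbers in this assay; its nearest neighbour is compound 1, which lies higher by the step of a number 25.9 percentage points lower from compound 1 to compound 2 (beyond the scatter). Compound 3 `CCCCCCCCCOC(=O)CCC(=O)N1CCN(CCCOc2cc3c(Nc4ccc(F)c(Cl)c4)ncnc3cc2OC)CC1` differs from compound 2 by ethyl in place of hydrogen on a saturated chain carbon, seven bonds along the chain from an oxygen next to a carbonyl group, a further lengthening of the same saturated chain on the ester side. Among the compounds with values here, the only measured step that bears on this change is a number 25.9 percentage points lower from compound 1 to compound 2 (beyond the scatter), where a larger lengthening of that chain, pentyl in place of hydrogen, brought a modest decrease beyond the scatter. A shorter extension by ethyl is therefore expected to move the number in the same direction but by less, possibly within the scatter. Compound 3 is thus expected to give 27% in this assay, with a range from 12% to 42%, the expected step being a number 8.7 percentage points lower from compound 2 to compound 3 (within the scatter).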

Compound 3, a percentage reported as activity, at one concentration (the size of the read-out at that concentration, not a potency): 10.3%
Beside the measured number, compound 3's estimate is 16.7 percentage points above it; the whole stated range lies above it.
By their numbers in this assay, from the lowest: compound 3; then compound 2; then compound 1.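

At the far end of the ester chain, the number was still falling: ethyl in place of hydrogen, seven bonds along the chain from an oxygen next to a carbonyl group, gave a number 25.4 percentage points lower from compound 2 to compound 3 (beyond the scatter) in this assay, a step also rated modest, although it adds fewer carbons than the pentyl step. Taken whole, heptyl in place of hydrogen gave a number 51.3 percentage points lower from compound 1 to compound 3 (beyond the scatter), and the number falls as the chain lengthens across all three compounds, with none going against this order. Nothing shown here gives a reason for this trend.

As far as these compounds go, whether a longer chain would lower the number further or the trend would level off remains open. So does the outcome for a branched chain, or for a chain ending in an amine or a carboxylic acid.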